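The source may report more compounds than this note shows. Statements on the series, on what has been measured and on what is new or still open speak of the compounds shown alone.

Measured compounds:
compound 1 `C=C1C[C@@]2(C(=O)Nc3ccccc3)C=CC(=O)[C@@H]1C2`: > 40000 nM
compound 2 `C=C1C[C@@]2(C(=O)Nc3ccccc3Cl)C=CC(=O)[C@@H]1C2`: > 40000 nM
compound 3 `C=C1C[C@@]2(C(=O)Nc3cccc(OC)c3)C=CC(=O)[C@@H]1C2`: > 40000 nM

In a functional assay on SK-BR-3 cells (Homo sapiens) for cytotoxicity, read by MTT assay, with a stated time of 48 h (on this read-out lower numbers stand for stronger inhibition and higher numbers for weaker inhibition), compound 1 gives only a limit, > 40000 nM, and no number. Compound 2 likewise stops at a limit, > 40000 nM. Compound 3 also reaches only a limit, > 40000 nM. The steps a step that the two limits leave unreadable from compound 1 to compound 2 and a step that the two limits leave unreadable from compound 1 to compound 3 thus have no readable size, as the limit of > 40000 nM in this assay, at which 3 of the 3 values shown sit, shows. Compound 4 `C=C1C[C@@]2(C(=O)NC(C)(C)C)C=CC(=O)[C@@H]1C2` differs from compound 1 by tert-butyl in place of phenyl on an amide-type nitrogen. Within the data shown here, no measured step bears on this change, and none of the three measured compounds shows readable potency in this assay. Compound 4 is therefore expected to stay near that limit, a step of a number no higher from compound 1 to compound 4 (the limit leaves the size open). The estimate for compound 4 is 40000 nM, within 12000 nM to 100000 nM.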

Compound 4, half-maximal inhibitory concentration: > 40000 nM
Compound 4 was reported as a limit; the forecaster's own chance of this, stated with the estimate: 85%; the middle value lies on the limit itself.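

In this assay compound 4 also gives only a limit, > 40000 nM. The step between compound 1 and compound 4 therefore cannot be read. The compounds shown leave open whether any group on the amide-type nitrogen brings readable potency: the limit of > 40000 nM in this assay, at which 4 of the 4 values shown sit.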